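From Cyclopropylmethyl to Propyl on the Amine Nitrogen

This account rests on a few compounds, and the source may have more. Where it says the series, first, only, none or still open, it means among the compounds named here.

Measured compounds:
Compound 1 `CCCC(c1ccccc1)N(CCC)c1nc(-c2ccc(OC)cc2C)n(C)n1`: in an in vitro assay on Ltk- cells for binding affinity to corticotropin-releasing factor receptor 1 (Homo sapiens) (on this read-out higher numbers stand for weaker inhibition and lower numbers for stronger inhibition), compound 1 gives 61 nM.
Compound 2 `CCCN(CC1CC1)c1nc(-c2ccc(Cl)cc2OC)n(C)n1`: in this assay compound 2 gives 2600 nM.
Compound 3 `CCCCC(CC)N(OCCC)c1nc(-c2ccc(Cl)cc2OC)n(C)n1`: in this assay compound 3 gives 280 nM.

Among these three numbers compound 2 stands highest, which on this read-out means the weakest inhibition. The nearest number is that of compound 3, and the furthest is that of compound 1; both gaps lie beyond the usual scatter of repeated measurements, so compound 2 is the weakest of the three. Compounds 1 and 3 differ from compound 2 in several places at once, so they give no direct reading of any single change.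

Compound 4 `CCCN(CCC)c1nc(-c2ccc(Cl)cc2OC)n(C)n1` differs from compound 2 in one place only: ethyl in place of cyclopropyl on a saturated chain carbon bound to a nitrogen on an aromatic ring. Within the data shown here, no measured pair in this set shows this change by itself, so there is nothing to copy from. Opening a small ring into a short chain of nearly the same size is a modest change, and the step from compound 2 to compound 4 in this assay is expected to be none beyond the scatter, as a 1.0-fold lower number from compound 2 to compound 4 (0.02 log units; within the scatter). Compound 4 is therefore estimated at 2500 nM, with a range from 800 nM to 8000 nM.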

Compound 4, inhibition constant: > 10000 nM
Compound 4: only a limit was reported (the forecaster's own chance of this, stated with the estimate: 5%); at least 4.0-fold (0.60 log units) between middle value and limit.
By their numbers in this assay, from the lowest: compound 1; then compound 3; then compound 2. At a limit, above all of these: compound 4.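

Among these compounds, compounds 1 and 3 differ from compound 2 in several places at once, so this pair gives the first reading of a single change in this assay: going from cyclopropylmethyl to propyl gives an at least 3.8-fold higher number from compound 2 to compound 4 (0.58 log units; beyond the scatter). With the rest of the molecule unchanged, the cyclopropyl ring therefore cannot be replaced by ethyl at this place without a loss of inhibition beyond the scatter, even though the two groups look alike in size. The value of compound 4 is a limit and not a number, so the full size of the step stays unknown: the limit of > 10000 nM in this assay, at which 1 of the 4 values shown sits.

This single pair cannot tell whether the loss follows from the missing ring or from the smaller count of heavy atoms in ethyl than in cyclopropyl, and a butyl chain or a cyclobutyl ring at the same place would help to separate the two. It also leaves open whether the same step would appear with the other groups on the nitrogen or on the aromatic ring seen in compounds 1 and 3.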